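Swapping the ketone aryl group: bromophenyl to naphthyl

This account rests on a few compounds, and the source may have more. Where it says the series, first, only, none or still open, it means among the compounds named here.

Compound 1 `CC(C)CC(=O)CC1Oc2cc(O)ccc2C=C1c1ccc(O)cc1` and compound 2 `O=C(CC1Oc2cc(O)ccc2C=C1c1ccc(O)cc1)c1ccc(Br)cc1` share one core and differ only in the group attached to a carbonyl carbon. In a functional assay on MDA-MB-231 cells (Homo sapiens) for antiproliferative activity, read by spectrophotometry and resazurin assay, with a stated time of 72 h (a lower number here means a stronger inhibitor, a higher number a weaker inhibitor), compound 1 gives 67000 nM. In this assay, among the measured compounds shown here, compound 2 gives 37000 nM; of the two numbers measured so far this is the lower one, yet the step of a 1.8-fold lower number from compound 1 to compound 2 (0.26 log units; within the scatter) lies within the scatter, so the two compounds cannot be told apart on these data.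

Compound 3 `O=C(CC1Oc2cc(O)ccc2C=C1c1ccc(O)cc1)c1cccc2ccccc12` is not yet measured. It differs from compound 2 in a single place: naphthalen-1-yl in place of 4-bromophenyl on a carbonyl carbon. For the measured compounds named here, the only measured step that bears on this change is a 1.8-fold lower number from compound 1 to compound 2 (0.26 log units; within the scatter), which altered the same carbonyl carbon and stayed within the scatter. Going by the values given here, with one such step as the sole guide, the expected step in this assay from compound 2 to compound 3 is a 1.2-fold lower number from compound 2 to compound 3 (0.09 log units; within the scatter), that is, nothing that clearly rises above the scatter in either direction. For compound 3 the estimated value in this assay is therefore 30000 nM, with a range from 12000 nM to 80000 nM.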

Compound 3, half-maximal inhibitory concentration: 106000 nM
Beside the measured number, compound 3's estimate is 3.5-fold (0.55 log units) below it, outside the stated range (above it).
By their numbers in this assay, from the lowest: compounds 2, 1 and 3 (each within the scatter of the next, the first and the last beyond it).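

In this assay the change at this carbonyl carbon gives a 2.9-fold higher number from compound 2 to compound 3 (0.46 log units; beyond the scatter) and this is the first step among these compounds to rise above the scatter, so 4-bromophenyl and naphthalen-1-yl cannot be treated as interchangeable here. An aromatic group on the carbonyl carbon is thus not enough to guarantee a number like that of compound 2, since replacing isobutyl with naphthalen-1-yl gives a 1.6-fold higher number from compound 1 to compound 3 (0.20 log units; within the scatter) and leaves compound 1 and compound 3 indistinguishable. Nothing available explains why these two aromatic groups differ.

The compounds shown leave open whether the difference follows the bromine atom or the second aromatic ring, a question that a plain phenyl group or a 4-chlorophenyl group on the same carbonyl carbon could help to separate. From the compounds shown here alone, it also remains open whether a group carrying an amine or a carboxylic acid at this place would move the number clearly in either direction.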